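The source may report more compounds than this note shows. Statements on the series, on what has been measured and on what is new or still open speak of the compounds shown alone.

Of the compounds shown here, three sharing one core have been measured in an assay on HEK293 cells for agonist activity at Toll-like receptor 2 (Homo sapiens); on this read-out lower numbers stand for an effect already at smaller amounts and higher numbers for an effect only at larger amounts of compound. Compound 1 `CCCCCCCCCCCC(=O)OC[C@H](CSC[C@@H](N)C(=O)NC(C)c1ccccc1)OC(=O)CCCCCCCCCCC` gives 9900 nM; compound 2 `CCCCCCCCCCCC(=O)OC[C@H](CSC[C@@H](N)C(=O)NC(C)CCC(C)C)OC(=O)CCCCCCCCCCC` gives 190 nM; compound 3 `CCCCCCCCCCCC(=O)OC[C@H](CSC[C@@H](N)C(=O)N[C@@H](CC)COCC(=O)O)OC(=O)CCCCCCCCCCC` gives 6500 nM. Compound 3 thus stands second highest of the three: its nearest neighbour is compound 1, and a 1.5-fold lower number from compound 1 to compound 3 (0.18 log units; within the scatter), a gap within the usual scatter; its furthest neighbour is compound 2, with a 34-fold higher number from compound 2 to compound 3 (1.53 log units; beyond the scatter).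

Compound 4 `CCCCCCCCCCCC(=O)OC[C@H](CSC[C@@H](N)C(=O)NCCN)OC(=O)CCCCCCCCCCC` is not yet measured. It differs from compound 3 in one place: 2-aminoethyl in place of 1-((carboxymethoxy)methyl)propyl on an amide-type nitrogen.

The measured steps show how much the group on the amide-type nitrogen can matter: a 52-fold lower number from compound 1 to compound 2 (1.72 log units; beyond the scatter), whereas a 1.5-fold lower number from compound 1 to compound 3 (0.18 log units; within the scatter). None of those steps involves the 2-aminoethyl group itself, so the direction for compound 4 cannot be read off directly. Given that two of the three amide substituents gave high numbers and one gave a far lower number, compound 4 is expected to land between them, with a 6.5-fold lower number from compound 3 to compound 4 (0.81 log units; beyond the scatter) as the estimated step. The estimate for compound 4 in this assay is 1000 nM, with a range from 150 nM to 8000 nM.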

Compound 4, half-maximal effective concentration: 5240 nM
The estimate for compound 4 lay 5.2-fold (0.72 log units) below the measured number; measured number inside the range.
By their numbers in this assay, from the lowest: compound 2; then compounds 4, 3 and 1 (each within the scatter of the next).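

In this assay, replacing the 9 heavy atoms of 1-((carboxymethoxy)methyl)propyl with the 3 of 2-aminoethyl on the amide-type nitrogen changes little, with a 1.2-fold lower number from compound 3 to compound 4 (0.09 log units; within the scatter), and swapping 1-phenylethyl for 2-aminoethyl also stays within the scatter, with a 1.9-fold lower number from compound 1 to compound 4 (0.28 log units; within the scatter). Among these four compounds, only the 1,4-dimethylpentyl group of compound 2 stands apart, with a 28-fold higher number from compound 2 to compound 4 (1.44 log units; beyond the scatter), so three differently built groups sit close together while this one branched carbon chain gives a clearly lower number. Nothing measured here explains why this group stands apart.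

The compounds shown leave open whether an unbranched hexyl chain on this nitrogen would give a number close to that of compound 2. They also leave open whether a hydroxyl or an amine at the end of the 1,4-dimethylpentyl chain would keep that low number.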